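The compounds below may be only part of what the source reports. "The series", "measured", "known", "first", "only" and "open" are said of these compounds alone.

Compound 1 `O=C(Nc1ncc(Cc2ccccn2)s1)C1CCCCC1` was tested in an ADME assay on P388D1 cells (Mus musculus) for cytotoxicity, read by fluorescence and resazurin assay, with a stated time of 72 h; a higher number here means a weaker inhibitor, a lower number a stronger inhibitor. In this assay compound 1 gives > 40000 nM, which is a limit of the assay and not a number. Among the measured compounds shown here, compound 2 `O=C(Nc1ncc(Cc2ccncc2)s1)C1CCCCC1`, whose reading in this assay is recorded as "not determined" (no result reported), stands without any number of its own; the only other value shown beside it is the limit of > 40000 nM in this assay, at which 1 of the 2 values shown sits. Compound 3 `O=C(Nc1ncc(Cc2ccccc2)s1)C1CCCCC1` differs from compound 2 in one place: phenyl in place of pyridin-4-yl on a saturated chain carbon bound to an aromatic carbon. For the measured compounds named here, no step between measured compounds is available, so the size of the change in this assay cannot be taken from a measured pair; the expectation is a step of no size beyond the usual scatter, with neither direction favoured. Compound 3 is therefore expected to sit near 40000 nM, with a range from 10000 nM to 100000 nM, because compound 1 with the same shared core reaches only > 40000 nM.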

Compound 3, half-maximal inhibitory concentration: > 40000 nM
Compound 3 was reported as a limit; the forecaster's own chance of this, stated with the estimate: 70%; the middle value sits exactly at the limit.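

Compound 1 and compound 3 are both reported only as limits in this assay, and the step between them cannot be read. The compounds shown leave open where compound 2 stands and whether any compound on this shared core gives a readable number in this assay.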